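The source may hold more compounds than are shown below. What is called first, only, known or untested is meant among the compounds shown, and "the series" means these compounds.

Working notes on the series. Compound 2 `CN(C(=O)c1ccco1)c1ccc2[nH]c(-c3n[nH]c4ccccc34)cc2n1` stands, in a functional assay on A549 cells (Homo sapiens) for antiproliferative activity, read by MTT assay, with a stated time of 72 h (on this read-out higher numbers stand for weaker inhibition and lower numbers for stronger inhibition), at 15500 nM, the higher of two numbers; compound 1 `CN(C(=O)c1ccccc1)c1ccc2[nH]c(-c3n[nH]c4ccccc34)cc2n1` gives 13800 nM, and the change a 1.1-fold higher number from compound 1 to compound 2 (0.05 log units; within the scatter) lies within the scatter. Compound 3 `CN(C(=O)Nc1ccccc1)c1ccc2[nH]c(-c3n[nH]c4ccccc34)cc2n1` differs from compound 2 by anilino in place of furan-2-yl on a carbonyl carbon. Among the measured compounds shown here, the only step that bears on it is the one from compound 1 to compound 2, an exchange of the aryl group on the same carbonyl carbon, and it moved nothing beyond the scatter. For the measured compounds named here, no measured step covers an anilino group on the carbonyl carbon, so no direction is expected beyond the scatter, and the step from compound 2 to compound 3 is estimated at a 1.2-fold lower number from compound 2 to compound 3 (0.08 log units; within the scatter). For compound 3 the expected value is 13000 nM, within 5000 nM to 35000 nM.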

Compound 3, half-maximal inhibitory concentration: 1430 nM
Compound 3: middle estimate off by 9.1-fold (0.96 log units), on the high side; the whole stated range lies above it.
By their numbers in this assay, from the lowest: compound 3; then compounds 1 and 2 (each within the scatter of the next).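

In this assay, the carbonyl carbon position proves responsive to the group it carries: anilino gives an 11-fold lower number from compound 2 to compound 3 (1.03 log units; beyond the scatter) and a 9.7-fold lower number from compound 1 to compound 3 (0.98 log units; beyond the scatter), whereas the exchange of phenyl for furan-2-yl stayed within the scatter. Anilino also brings a hydrogen-bond donor that furan-2-yl lacks, so donor count and potency change together in this one comparison. Nothing available explains the gain.

Going by these compounds, it remains open whether the gain follows the anilino nitrogen hydrogen or the phenyl ring. A methylated anilino, benzylamino or cyclohexylamino group at this carbonyl carbon would help separate the two.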